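A few compounds are considered here, and "the series" means these few. Any claim that something is new, unique, unknown or untested is made for them only; others in the source may bear on it.

Of the compounds shown here, two sharing one core have been measured in a functional assay on HOS cells (Homo sapiens) for inhibition, with a stated time of 72 h; a higher number here means a weaker inhibitor, a lower number a stronger inhibitor. Compound 1 (`NC1CCC(Nc2nc(NCc3ccc(Br)cc3)c3ncn(C4CCCC4)c3n2)CC1`) gives 995 nM, and compound 2 (`NC1CCC(Nc2nc(NCc3ccc(-c4ccccc4)cc3)c3ncn(C4CCCC4)c3n2)CC1`) gives 290 nM, the lower of the two numbers. Compound 3 (`COc1ccccc1-c1ccc(CNc2nc(NC3CCC(N)CC3)nc3c2ncn3C2CCCC2)cc1`) has not yet been measured. It differs from compound 2 by methoxy in place of hydrogen on an aromatic carbon, ortho to a large group, so that phenyl becomes 2-methoxyphenyl.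

Among the measured compounds shown here, only one measured step bears on this change, and it does so indirectly. That step introduced the phenyl which carries the methoxy in compound 3, with phenyl in place of bromo on an aromatic carbon. For the measured compounds named here, no measured compound carries a methoxy, so the direction of the new step remains open. Going by the values given here, with a 3.4-fold lower number from compound 1 to compound 2 (0.54 log units; beyond the scatter) as the only guide, a step no larger than that modest one is expected, quite possibly none beyond the scatter. The expected change is a 1.2-fold lower number from compound 2 to compound 3 (0.06 log units; within the scatter). In this assay compound 3 is expected at 250 nM, with an estimated range from 100 nM to 620 nM.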

Compound 3, half-maximal inhibitory concentration: 150 nM
Beside the measured number, compound 3's estimate is 1.7-fold (0.22 log units) above it; low and high end bracket the measured number.
By their numbers in this assay, from the lowest: compounds 3 and 2 (each within the scatter of the next); then compound 1.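

In this assay, adding methoxy to the outer phenyl, on an aromatic carbon ortho to a large group, gives a 1.9-fold lower number from compound 2 to compound 3 (0.29 log units; within the scatter). This step lies within the scatter, so compound 2 and compound 3 cannot be told apart, and the position is shown to accept a group with one hydrogen-bond acceptor and two heavy atoms without a change that can be read. The 2-methoxyphenyl group also stands clear of the bromo group of the first compound, with a 6.6-fold lower number from compound 1 to compound 3 (0.82 log units; beyond the scatter), a step beyond the scatter, so the difference seen with phenyl in place of bromo is kept once methoxy is present; nothing available explains these numbers.

The compounds shown leave open whether a hydroxyl group, an amine or a carboxylic acid on the same aromatic carbon would give a number like that of methoxy, or whether a longer chain such as ethoxy or butoxy would move it beyond the scatter. They also leave open how methoxy would read on any other carbon of that phenyl ring.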